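Benzyl to hydroxy on the ring carbon: compound 3

The source may report more compounds than this note shows. Statements on the series, on what has been measured and on what is new or still open speak of the compounds shown alone.

Measured so far in a functional assay on DA-3 cells for cytotoxicity against DA-3 cell line (Mus musculus), read by MTT assay; a lower number here means a stronger inhibitor, a higher number a weaker inhibitor:
- compound 1, `CC(=O)O[C@@H]1OC(=O)[C@@](C)(C(C)=O)[C@@H]1C`, gives 9000 nM
- compound 2, `CC(=O)O[C@@H]1OC(=O)[C@@](Cc2ccccc2)(C(C)=O)[C@@H]1C`, gives 44000 nM

Among the measured compounds shown here, compound 2 holds the higher of the two numbers; its only neighbour is compound 1, from which it is separated by the step of a 4.9-fold higher number from compound 1 to compound 2 (0.69 log units; beyond the scatter), a change that put phenyl in place of hydrogen on a saturated chain carbon bound to a saturated ring carbon.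

Compound 3, `CC(=O)O[C@@H]1OC(=O)[C@@](O)(C(C)=O)[C@@H]1C`, differs from compound 2 by hydroxy in place of benzyl on a saturated ring carbon. For the measured compounds named here, the one measured step that bears on this is a 4.9-fold higher number from compound 1 to compound 2 (0.69 log units; beyond the scatter): the benzyl that entered there now leaves again, which on its own argues for a return toward the number of compound 1. Hydroxy, however, enters in place of hydrogen, and no measured compound carries hydroxy at this ring carbon, so the size of that part is unknown. On balance a drop beyond the scatter is expected, a 3.7-fold lower number from compound 2 to compound 3 (0.56 log units; beyond the scatter), landing near compound 1 rather than further. The estimate for compound 3 in this assay is 12000 nM, with a range from 4000 nM to 40000 nM.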

Compound 3, half-maximal inhibitory concentration: > 50000 nM
Compound 3 was reported as a limit (the forecaster's own chance of this, stated with the estimate: 10%); middle value at least 4.1-fold (0.61 log units) away from the limit.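

In this assay compound 3 gives no number, only a limit of the assay: the limit of > 50000 nM in this assay, at which 1 of the 3 values shown sits. Taking benzyl off this saturated ring carbon and putting hydroxy there does not bring the number back toward that of the methyl analogue, and the reading of an at least 1.1-fold higher number from compound 2 to compound 3 (0.05 log units; that floor lies within the scatter) leaves the two compounds unordered, so hydroxy cannot be called better or worse than benzyl here. Set against methyl, the same position gives an at least 5.5-fold higher number from compound 1 to compound 3 (0.74 log units; beyond the scatter), which adds a second departure from methyl, after benzyl, that goes the same way, and compound 1 remains the strongest of the three in this assay.

On these data alone, how far the true value of compound 3 lies past its limit stays open, and with it any real ranking of hydroxy against benzyl. Also open, as far as these compounds go, is whether anything at this ring carbon does better than methyl: an ethyl or a methoxy group would show whether the preference is narrow to methyl, while the acetoxy group, unchanged in all three compounds, remains untested.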